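Dropping One Ring Fluorine: What Shift to Expect

The compounds below may be only part of what the source reports. "The series", "measured", "known", "first", "only" and "open" are said of these compounds alone.

Compound 1 `COc1cccc(/C=C/c2ccc(F)cc2)c1OC` gives 2900 nM in an assay on HepG2 cells for activation of nuclear factor erythroid 2-related factor 2 (Homo sapiens), read by a luciferase reporter, with a stated time of 5 h; on this read-out lower numbers stand for an effect already at smaller amounts and higher numbers for an effect only at larger amounts of compound.
Compound 2 `Fc1cccc(/C=C/c2cccc(F)c2)c1` gives 1000 nM in this assay.
Compound 3 `Fc1cccc(/C=C/c2cc(F)ccc2F)c1` gives 300 nM in this assay.

Among these three, compound 1 shows the highest number. Compound 3 and compound 2 differ in one place: hydrogen in place of fluoro on an aromatic carbon. That step gave a 3.3-fold higher number from compound 3 to compound 2 (0.52 log units; beyond the scatter). The difference between the core of compound 1 and the core of compound 3 is not broken down here.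

Compound 4 `COc1cccc(/C=C/c2ccccc2)c1OC` has not yet been measured. It differs from compound 1 by hydrogen in place of fluoro on an aromatic carbon. For the measured compounds named here, this is the same kind of change as the one from compound 3 to compound 2, though the surroundings differ: in compound 3 the fluoro sits ortho to a group of 9 heavy atoms and para to a fluoro group, while in compound 1 it sits para to a large group. Resting on the step from compound 3 to compound 2, the expected step from compound 1 to compound 4 in this assay is a 2.4-fold higher number from compound 1 to compound 4 (0.38 log units; beyond the scatter), of a size like that earlier one. Compound 4 is therefore estimated at 7000 nM, expected between 2500 nM and 20000 nM.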

Compound 4, half-maximal effective concentration: 4700 nM
Estimate against measurement, compound 4: 1.5-fold (0.17 log units) above; the measured number falls inside the stated range.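

In this assay, the new step is a 1.6-fold higher number from compound 1 to compound 4 (0.21 log units; within the scatter), so on this core, replacing the fluoro with hydrogen cannot be told apart from no change at all. Set beside the earlier step, the result gives no sign that the two cores respond differently to this change: the same change on two cores in this assay, a 3.3-fold higher number (0.52 log units; beyond the scatter) from compound 3 to compound 2 and a 1.6-fold higher number (0.21 log units; within the scatter) from compound 1 to compound 4, 2.1-fold (0.31 log units) apart, within the scatter of two such steps. For the compounds shown here, this does not show that the change has one fixed size on every core, however: only two pairs are available, one of the two steps alone lies beyond the scatter, and the fluoro stands in different surroundings in the two pairs.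

The compounds shown leave open whether a different group in the same place on the core of compound 1, such as a chlorine, an amine or a carboxylic acid, would shift the number by more than the fluoro does. They also leave open whether replacing a fluoro with hydrogen would give a similar step on a third core.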